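This account rests on a few compounds, and the source may have more. Where it says the series, first, only, none or still open, it means among the compounds named here.

Compound 3 `O=C(NCc1ccc(CNS(=O)(=O)c2cccc(F)c2)cc1)c1cccnc1` stands as the highest of the two numbers reported in an assay on MDA-MB-231 cells for displacement of a labelled ligand from C-X-C chemokine receptor type 4 (Homo sapiens), read by fluorescence and microscopy, with stated times of 10 min and 30 min (on this read-out higher numbers stand for an effect only at larger amounts of compound and lower numbers for an effect already at smaller amounts), where compound 3 gives 1000 nM. Its nearest neighbour is compound 1 `COc1ccccc1C(=O)NCc1ccc(CNS(=O)(=O)c2ccc([N+](=O)[O-])cc2)cc1`, which in this assay gives 100 nM, a number that lies beyond the scatter from that of compound 3. Compound 2 `COc1ccccc1C(=O)NCc1ccc(CNS(=O)(=O)c2cccc3ccccc23)cc1` appears in this assay only as a limit, > 1000 nM. Among the measured compounds shown here, the single measured step in this set, an at least 10-fold higher number from compound 1 to compound 2 (1.00 log units; beyond the scatter), concerns the group on the sulfonyl sulfur and rests on the limit (the limit of > 1000 nM in this assay, at which 1 of the 3 values shown sits). Compound 4 `COc1ccccc1C(=O)NCc1ccc(CNS(=O)(=O)c2cccc(F)c2)cc1` differs from compound 3 at the carbonyl carbon: 2-methoxyphenyl in place of pyridin-3-yl on a carbonyl carbon. For the measured compounds named here, no measured step touches the carbonyl side, so this change has no direct precedent here; compound 1, which carries 2-methoxyphenyl on its carbonyl carbon, also differs from compound 3 on the sulfonyl sulfur, so its value cannot be read across. One therefore expects a step of a 1.4-fold lower number from compound 3 to compound 4 (0.15 log units; within the scatter) in this assay, lying within the scatter in either direction. Compound 4 is estimated at 700 nM in this assay, with a range from 200 nM to 3000 nM.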

Compound 4, effective concentration (reported as EC, without a stated level of effect): 1000 nM
Estimate against measurement, compound 4: 1.4-fold (0.15 log units) below; low and high end bracket the measured number.
By their numbers in this assay, from the lowest: compound 1; then compounds 3 and 4 (each within the scatter of the next).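

Among the compounds shown here, the first measured step on the carbonyl carbon puts 2-methoxyphenyl in place of pyridin-3-yl on a carbonyl carbon, with 3-fluorophenyl held on the sulfonyl sulfur: in this assay there is no change at the digits printed from compound 3 to compound 4 (within the scatter). Compound 4 also gives a step with 2-methoxyphenyl held on the carbonyl carbon, a 10-fold higher number from compound 1 to compound 4 (1.00 log units; beyond the scatter), which places both readable steps beyond the scatter in these compounds on the sulfonyl sulfur. Compound 2 stands at a limit. The size of the remaining step, a number no higher from compound 2 to compound 4 (the limit leaves the size open), therefore cannot be read: the limit of > 1000 nM in this assay, at which 1 of the 4 values shown sits.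

From the compounds shown here alone, it remains open whether the carbonyl side would stay as silent with 4-nitrophenyl on the sulfonyl sulfur. Also open, going by these compounds, is what a carboxylic acid, an amine or a longer chain would give in place of pyridin-3-yl on a carbonyl carbon.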